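Fluorine pattern on the benzyl group: compound 2 to compound 3

The source may report more compounds than this note shows. Statements on the series, on what has been measured and on what is new or still open speak of the compounds shown alone.

Measured compounds:
compound 1 `CC1(C)c2[nH]nc(NC(=O)c3ccc4ncccc4c3)c2CN1Cc1cc(F)cc(F)c1` — 180 nM
compound 2 `CN(C)c1cccc(C(=O)Nc2n[nH]c3c2CN(Cc2cccc(F)c2F)C3(C)C)c1` — 420 nM

In an assay on Sf21 cells for inhibition of high affinity nerve growth factor receptor (Homo sapiens), read by HTRF, with a stated time of 30 min, in the presence of a further agent that is not named here (a higher number here means a weaker inhibitor, a lower number a stronger inhibitor), compound 2 gives 420 nM, the higher of the two numbers; compound 1 gives 180 nM, a gap beyond the scatter, though the two compounds differ in more than one place. Compound 3 `CN(C)c1cccc(C(=O)Nc2n[nH]c3c2CN(Cc2cc(F)cc(F)c2)C3(C)C)c1` carries 3,5-difluorophenyl in place of 2,3-difluorophenyl on a saturated chain carbon bound to an amine nitrogen in a ring. Among the measured compounds shown here, no single-change step is available for this swap, so the direction is taken from compound 1, which carries the same 3,5-difluorobenzyl group at 180 nM. A modest drop, a 1.5-fold lower number from compound 2 to compound 3 (0.18 log units; within the scatter), is expected. Compound 3 is estimated at 280 nM, range 100 nM to 800 nM.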

Compound 3, half-maximal inhibitory concentration: 270 nM
Estimate against measurement, compound 3: 1.0-fold (0.02 log units) above; measured number inside the range.
By their numbers in this assay, from the lowest: compounds 1, 3 and 2 (each within the scatter of the next, the first and the last beyond it).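

In this assay the change from 2,3-difluorophenyl to 3,5-difluorophenyl on a saturated chain carbon bound to an amine nitrogen in a ring gives a 1.6-fold lower number from compound 2 to compound 3 (0.19 log units; within the scatter) and so does not separate the two fluorine patterns. With 3,5-difluorobenzyl held constant, 3-(dimethylamino)phenyl in place of quinolin-6-yl on a carbonyl carbon gives a 1.5-fold higher number from compound 1 to compound 3 (0.18 log units; within the scatter) and these two groups cannot be told apart either. No supporting data bear on these results.

Open, as far as these compounds go, is how an unsubstituted benzyl group, a chlorobenzyl group or a longer chain would read at this position.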